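Three measured compounds and one halogen exchange

The source may hold more compounds than are shown below. What is called first, only, known or untested is meant among the compounds shown, and "the series" means these compounds.

Within the data shown here, the series so far holds three measured compounds. Compound 1 `O=C(/C=C/c1ccc(I)cc1)c1ccc(OCB(O)O)cc1` gives 18000 nM in a functional assay on MDA-MB-435 cells (Homo sapiens) for inhibition; on this read-out lower numbers stand for stronger inhibition and higher numbers for weaker inhibition. Compound 2 `O=C(/C=C/c1ccc(F)c(Br)c1)c1ccc(B(O)O)cc1` gives 8800 nM in this assay, and compound 3 `O=C(O)COc1ccc(/C=C/C(=O)c2ccc(Cl)c(Cl)c2)cc1` gives 13000 nM. Of these three numbers, compound 2 has the lowest; its gap to compound 3 lies within the scatter of repeated measurements, so no order between the two can be claimed, while its gap to compound 1 lies beyond it. Among the measured compounds shown here, no two of the measured compounds differ in a single place, so no measured step is available.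

Compound 4 `O=C(/C=C/c1ccc(F)c(F)c1)c1ccc(B(O)O)cc1` is not yet measured. It differs from compound 2 in one place: fluoro in place of bromo on an aromatic carbon. The exchange sits on an aromatic carbon that is ortho to a fluoro group and meta to a large group, and it leaves ring count, donors, acceptors and charge unchanged.

With no measured step of this kind in the set, the expectation rests on the change alone. The expected shift is a 1.4-fold higher number from compound 2 to compound 4 (0.13 log units; within the scatter), a small move toward a higher number that is not expected to stand clearly beyond the scatter. Compound 4 is expected to give about 12000 nM in this assay, with a range from 5000 nM to 30000 nM.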

Compound 4, half-maximal inhibitory concentration: 8800 nM
Compound 4: middle estimate off by 1.4-fold (0.13 log units), on the high side; measured number inside the range.
By their numbers in this assay, from the lowest: compounds 2, 4, 3 and 1 (each within the scatter of the next, the first and the last beyond it).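

In this assay, among these compounds, fluoro in place of bromo on this aromatic carbon, ortho to a fluoro group and meta to a large group, gives no change at the digits printed from compound 2 to compound 4 (within the scatter) and provides the first measured single-place step. Among the compounds shown here, at this position, the read-out does not separate bromo from fluoro, something the earlier compounds could not show, as no two of them differed in one place only. The exchange of one halogen for the other therefore leaves the number intact on this core, though this rests on a single pair, and nothing available accounts for the flat step.

As far as these compounds go, what an amine, a methoxy group or a carboxylic acid on this same aromatic carbon would do to the number remains open, since only two halogens have been compared there. From the compounds shown here alone, it is also open whether the flat step would hold for chloro or iodo at this carbon, or on a ring without the neighbouring fluoro group.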